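Trading the 5-Chlorothiophen-2-yl Group for Methyl

A few compounds are considered here, and "the series" means these few. Any claim that something is new, unique, unknown or untested is made for them only; others in the source may bear on it.

Measured so far:
compound 1 `Cn1nc(C(F)(F)F)c2c(-c3ccccc3)cc(NNC(=O)Nc3cc(Cl)nc(Cl)c3)nc21` gives 18100 nM
compound 2 `Cc1nn(C)c2nc(NNC(=O)Nc3cc(Cl)nc(Cl)c3)cc(-c3ccc(Cl)s3)c12` gives 42100 nM
compound 3 `COc1ccc(-c2cc(NNC(=O)Nc3cc(Cl)nc(OC)c3)nc3c2cnn3C)cc1` gives 54200 nM

All three were tested in a functional assay on HCT-116 cells (Homo sapiens) for cytotoxicity, read by MTT assay, with a stated time of 48 h, in the presence of a further agent that is not named here; a higher number here means that more compound is needed for the effect, a lower number that less compound is needed. Among the three numbers, compound 2 holds the second highest place; its value sits within the usual scatter of compound 3, while compound 1 lies beyond that scatter at a lower number, so compound 1 is the only one that can be said to need less compound than compound 2.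

Compound 4 `Cc1cc(NNC(=O)Nc2cc(Cl)nc(Cl)c2)nc2c1c(C)nn2C` has not been measured. It differs from compound 2 in one place: methyl in place of 5-chlorothiophen-2-yl on an aromatic carbon. The group that leaves is a five-membered aromatic ring with 1 hetero atom carrying a chlorine; what enters is a single carbon with no ring.

Every measured compound carries an aromatic ring at this position, so nothing here shows directly what losing that ring does. Because compound 1, compound 2 and compound 3 all sit at high numbers in this assay, the estimate for compound 4 is a modest step toward a higher number, a 1.7-fold higher number from compound 2 to compound 4 (0.22 log units; within the scatter), though the step may fall within the scatter. Compound 4 is expected to give about 70000 nM, with a range from 25000 nM to 200000 nM.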

Compound 4, half-maximal effective concentration: > 100000 nM
Compound 4 ended at the assay's limit; the forecaster's own chance of this, stated with the estimate: 25%; middle value at least 1.4-fold (0.15 log units) away from the limit.
By their numbers in this assay, from the lowest: compound 1; then compounds 2 and 3 (each within the scatter of the next). At a limit, above all of these: compound 4.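

In this assay, replacing the 5-chlorothiophen-2-yl group with methyl brings an at least 2.3-fold higher number from compound 2 to compound 4 (0.37 log units; beyond the scatter). Among these compounds, this is the first direct look at this position, on an aromatic carbon opposite the ring nitrogen, without a ring attached, and it shows that a single carbon does not preserve the measurable effect seen with compound 2. The value of compound 4 is a limit of the assay and not a number, so the step gives only a minimum size: the limit of > 100000 nM in this assay, at which 1 of the 4 values shown sits.

The compounds shown leave open whether the thiophene ring or its chlorine accounts for the difference, which a plain thiophen-2-yl group at this position could help separate. Also open, on these data alone, is what an ethyl chain or an amine would give there, and whether either would fall closer to compound 2 or to compound 4.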